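Piperidine substituent change in the shared core

This account rests on a few compounds, and the source may have more. Where it says the series, first, only, none or still open, it means among the compounds named here.

Compound 2 `Cc1nc(OC2CCN(C(=O)OC(C)(C)C)CC2)c2c(n1)N(c1ccc(S(C)(=O)=O)cc1F)CC2` gives, in a functional assay on CHO-K1 cells with Glucose-dependent insulinotropic receptor (Homo sapiens) as the target, read by a luciferase reporter, with a stated time of 5 h (on this read-out lower numbers stand for smaller maximal responses and higher numbers for larger maximal responses), 69%. Among the two measured compounds it stands lowest; its only neighbour, compound 1 `CC(C)(C)OC(=O)N1CCC(Oc2ncnc3c2CCN3c2ccc(S(C)(=O)=O)cc2F)CC1`, gives 139%, and the one measured step, a number 70 percentage points lower from compound 1 to compound 2 (beyond the scatter), is a methyl in place of hydrogen on an aromatic carbon.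

Compound 3 `Cc1nc(OC2CCN(c3nc(C(C)C)no3)CC2)c2c(n1)N(c1ccc(S(C)(=O)=O)cc1F)CC2` is not yet measured. It differs from compound 2 by 3-isopropyl-1,2,4-oxadiazol-5-yl in place of tert-butoxycarbonyl on an amine nitrogen in a ring. The methyl on the aromatic carbon of compound 2 is kept, so the measured step between compound 1 and compound 2 does not bear on this change: it concerns a different place in the shared core and a different pair of groups. Within the data shown here, no measured step addresses an exchange on the amine nitrogen in the ring, so nothing in the numbers so far tells the direction or size of the step to compound 3.

For compound 3 the expected step is therefore a number 11 percentage points higher from compound 2 to compound 3 (beyond the scatter), centred close to the number of compound 2 with a wide range to either side. Compound 3 is estimated at 80%, between 45% and 125%.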

Compound 3, largest response reached (reported as percent of maximum), in percent of the reference or control that the assay uses: 44%
The estimate for compound 3 lay 36 percentage points above the measured number, and the stated range ends above it.
By their numbers in this assay, from the lowest: compound 3; then compound 2; then compound 1.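

The exchange on the amine nitrogen in the ring now has a measured size in this assay: with the methyl on the aromatic carbon kept, 3-isopropyl-1,2,4-oxadiazol-5-yl in place of tert-butoxycarbonyl gives a number 25 percentage points lower from compound 2 to compound 3 (beyond the scatter) in the maximal response, so this position is not silent. The pair shows that the read-out responds at a second place in the series, and compound 3 at 44% still gives a clear response with an aromatic five-membered ring in place of an open group. Nothing at hand explains the step or says which of the differences between the two groups carries it.

The compounds shown do not tell whether the same exchange would give a step of similar direction and size on the core of compound 1, which lacks the methyl on the aromatic carbon. They also leave open what a methyl or a cyclopropyl in place of the isopropyl on the oxadiazole would give, or what a simple acetyl or a pyrimidin-2-yl group would give on the same ring nitrogen.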